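The source may report more compounds than this note shows. Statements on the series, on what has been measured and on what is new or still open speak of the compounds shown alone.

Compound 1 `CC(C)(C)c1ccc(C(=O)/C=C/C(=O)O)cc1` gives 8740 nM in a functional assay on LS174T cells (Homo sapiens) for inhibition, read by MTT assay, with a stated time of 72 h; a higher number here means a weaker inhibitor, a lower number a stronger inhibitor.
Compound 2 `CCCCCCCCCCCCc1ccc(C(=O)/C=C/C(=O)O)cc1` gives 7850 nM in this assay.

Compound 2 holds the lowest of the two numbers, but compound 1 is its nearest neighbour and the gap between them lies within the scatter, so the two are not separated. Compound 3 `CCCCc1ccc(C(=O)/C=C/C(=O)O)cc1` is not yet measured; it differs from compound 2 by hydrogen in place of octyl on a saturated chain carbon, four bonds along the chain from an aromatic carbon. Among the measured compounds shown here, no step between measured compounds is available. Because compound 1 at 8740 nM and compound 2 at 7850 nM sit together despite their different chains, no step beyond the scatter is expected in this assay in either direction. For compound 3 the estimate is 8500 nM, expected to fall between 4000 nM and 18000 nM. The expected step is a 1.1-fold higher number from compound 2 to compound 3 (0.03 log units; within the scatter).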

Compound 3, half-maximal inhibitory concentration: 6740 nM
The estimate for compound 3 lay 1.3-fold (0.10 log units) above the measured number, within the range that was stated.
By their numbers in this assay, from the lowest: compounds 3, 2 and 1 (each within the scatter of the next).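

In this assay the step of a 1.2-fold lower number from compound 2 to compound 3 (0.07 log units; within the scatter) goes with hydrogen in place of octyl on a saturated chain carbon, four bonds along the chain from an aromatic carbon, so removing octyl here does not separate the two compounds. The step of a 1.3-fold lower number from compound 1 to compound 3 (0.11 log units; within the scatter) goes with butyl in place of tert-butyl on an aromatic carbon, so the straight and branched chains are not separated either. Nothing measured here bears on why these chains sit together. Still open, on these data alone, is whether an amine or a hydroxyl on the chain, or a phenyl ring in its place, would give a step beyond the scatter.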